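Halogen swap on the hydroxyphenyl ring: cytotoxicity working notes

The compounds below may be only part of what the source reports. "The series", "measured", "known", "first", "only" and "open" are said of these compounds alone.

Measured so far, in a functional assay on HepG2 cells (Homo sapiens) for cytotoxicity, with a stated time of 24 h; on this read-out lower numbers stand for stronger inhibition and higher numbers for weaker inhibition:
compound 1, `COc1ccc(Cl)cc1C(=S)Nc1ccc(Cl)cc1O`, gives 4450 nM.
compound 2, `COc1ccc(Cl)cc1C(=S)Nc1cc(Cl)ccc1O`, gives 8600 nM.
compound 3, `COc1ccc(Cl)cc1C(=S)Nc1ccc(Br)cc1O`, gives 7600 nM.

Compound 1 and compound 2 share the same atoms joined differently; the difference between the two cores is not broken down here. Compound 3 differs from compound 1 by bromo in place of chloro on an aromatic carbon, and the step of a 1.7-fold higher number from compound 1 to compound 3 (0.23 log units; within the scatter). Compound 4, `COc1ccc(Cl)cc1C(=S)Nc1cc(Br)ccc1O`, still unmeasured, differs from compound 2 by bromo in place of chloro on an aromatic carbon. This is the same kind of change, though the place differs: on the core of compound 1 it sits meta to a hydroxy group and para to a large group, on the core of compound 2 meta to a large group and para to a hydroxy group. Since compound 1 to compound 3 moved a 1.7-fold higher number from compound 1 to compound 3 (0.23 log units; within the scatter), the step from compound 2 to compound 4 is expected to be of similar size, a 1.3-fold higher number from compound 2 to compound 4 (0.11 log units; within the scatter), in this assay. Compound 4 is thus estimated at 11000 nM, between 5000 nM and 25000 nM.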

Compound 4, half-maximal inhibitory concentration: 8740 nM
The estimate for compound 4 lay 1.3-fold (0.10 log units) above the measured number, within the range that was stated.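

Bromo in place of chloro on the core of compound 2 gives a 1.0-fold higher number from compound 2 to compound 4 (0.01 log units; within the scatter) in this assay. Set beside the same change on the core of compound 1, the two steps do not differ beyond the scatter: the same change on two cores in this assay, a 1.7-fold higher number (0.23 log units; within the scatter) from compound 1 to compound 3 and a 1.0-fold higher number (0.01 log units; within the scatter) from compound 2 to compound 4, 1.7-fold (0.23 log units) apart, within the scatter of two such steps. This shows that, on these two cores, the change carries over without a detectable difference between the steps, but with each step itself within the scatter, it does not show that the swap has any effect on either core, and two pairs establish no rule for the wider series.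

The compounds shown leave open whether a group other than chloro or bromo at this place, such as an amine or a carboxylic acid, would move the number beyond the scatter. They also leave open whether the hydroxy group is needed, since it stays in place on all four compounds.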